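A few compounds are considered here, and "the series" means these few. Any claim that something is new, unique, unknown or untested is made for them only; others in the source may bear on it.

Compound 1 `CCC/C(=C(/c1ccc(/C=C/C(=O)O)cc1)c1ccc2[nH]ncc2c1)c1ccccc1`: 11 nM
Compound 2 `COC/C(=C(/c1ccc(/C=C/C(=O)O)cc1)c1ccc2[nH]ncc2c1)c1ccccc1`: 88 nM
Compound 3 `O=C(O)/C=C/c1ccc(/C(=C(\c2ccccc2)C(F)F)c2ccc3[nH]ncc3c2)cc1`: 14 nM

In a functional assay on MCF7 cells (Homo sapiens) for cytotoxicity, read by CellTiter-Glo, with a stated time of 5 days (on this read-out higher numbers stand for weaker inhibition and lower numbers for stronger inhibition), compound 3 gives 14 nM, the second highest of the three numbers. Its nearest neighbour is compound 1, the step being a 1.3-fold higher number from compound 1 to compound 3 (0.10 log units; within the scatter), within the scatter; the step from the furthest neighbour, a 6.3-fold lower number from compound 2 to compound 3 (0.80 log units; beyond the scatter), lies beyond it. Compound 4 `O=C(O)/C=C/c1ccc(/C(=C(\c2ccccc2)C2CCCCC2)c2ccc3[nH]ncc3c2)cc1` differs from compound 3 in one place: cyclohexyl in place of difluoromethyl on a double-bonded chain carbon bound to an aromatic carbon and a double-bonded chain carbon. Going by the values given here, three steps touch this position of the shared core: an 8.0-fold higher number from compound 1 to compound 2 (0.90 log units; beyond the scatter), a 1.3-fold higher number from compound 1 to compound 3 (0.10 log units; within the scatter) and a 6.3-fold lower number from compound 2 to compound 3 (0.80 log units; beyond the scatter). Propyl and difluoromethyl gave numbers within the scatter of each other; only methoxymethyl gave a modestly higher number. Cyclohexyl, like propyl, is carbon only, and no measured step covers a ring at this place. On this basis compound 4 is expected to stay close to compound 3 in this assay, the expected step being a 1.3-fold higher number from compound 3 to compound 4 (0.11 log units; within the scatter), with no change beyond the scatter. The estimate for compound 4 is 18 nM, expected within 5 nM to 70 nM.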

Compound 4, half-maximal inhibitory concentration: 64 nM
Estimate against measurement, compound 4: 3.6-fold (0.55 log units) below, within the range that was stated.
By their numbers in this assay, from the lowest: compounds 1 and 3 (each within the scatter of the next); then compounds 4 and 2 (each within the scatter of the next).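

In this assay cyclohexyl puts a ring on the double-bonded chain carbon, and it does not read like difluoromethyl or propyl, with a 4.6-fold higher number from compound 3 to compound 4 (0.66 log units; beyond the scatter) and a 5.8-fold higher number from compound 1 to compound 4 (0.76 log units; beyond the scatter) both beyond the scatter. Its number instead lies with that of methoxymethyl, the step being a 1.4-fold lower number from compound 2 to compound 4 (0.14 log units; within the scatter) and within the scatter, so among these four compounds a carbon-only group at this place does not in itself go with a low number. No measurement here accounts for this result.

As far as these compounds go, whether a smaller ring such as cyclopropyl or an open hexyl chain would read like propyl or like cyclohexyl stays open. So does the reading of an amine at this place, on the same shared core.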